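A few compounds are considered here, and "the series" means these few. Any claim that something is new, unique, unknown or untested is made for them only; others in the source may bear on it.

Compound 2 `Cc1ccccc1OCc1ccccc1-c1nc(COc2ccc(Cl)cc2)cs1` stands at the smaller of the two numbers measured in a functional assay on the whole organism (strain Wistar albino) for inhibition, with Rattus norvegicus as the target, read by paw edema, at a dose of 10 mg/kg by the oral route (on this read-out lower numbers stand for less inhibition and higher numbers for more inhibition at the one dose given (going by the name of the read-out)), where compound 2 gives 65.1%; compound 1 `Cc1ccc(OCc2ccccc2-c2nc(-c3cc(Cl)sc3S(N)(=O)=O)cs2)cc1` gives 68.7% in this assay, a gap within the scatter, so the two cannot be told apart. Compound 3 `Cc1ccc(OCc2ccccc2-c2nc(COc3ccc(Cl)cc3)cs2)cc1` differs from compound 2 by 4-methylphenyl in place of 2-methylphenyl on an oxygen on a saturated carbon. For the measured compounds named here, no step between measured compounds is available to guide the size of this change, so nothing beyond the scatter is expected. The estimate for compound 3 in this assay is 65%, with a range from 50% to 78%. The expected step of a number 0.1 percentage points lower from compound 2 to compound 3 (within the scatter) is estimated to lie within the scatter.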

Compound 3, a percentage reported as inhibition, in the whole organism at one dose (the size of the read-out at that dose, not a potency): 68.7%
Compound 3: middle estimate off by 3.7 percentage points, on the low side, within the range that was stated.
By their numbers in this assay, from the lowest: compounds 2, 1 and 3 (each within the scatter of the next).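

In this assay, 4-methylphenyl in place of 2-methylphenyl on an oxygen on a saturated carbon gives a number 3.6 percentage points higher from compound 2 to compound 3 (within the scatter), so this change does not separate the two compounds. Likewise, (4-chlorophenoxy)methyl in place of 5-chloro-2-sulfamoylthiophen-3-yl on an aromatic carbon gives no change at the digits printed from compound 1 to compound 3 (within the scatter), so neither change shifts the read-out at this single dose beyond the scatter. Going by these compounds, it remains open whether a carboxylic acid or an amine in place of the methyl on this phenyl group would move the number beyond the scatter. No supporting evidence bears on these results.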